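The compounds below may be only part of what the source reports. "The series", "measured", "known", "first", "only" and "open" are said of these compounds alone.

Within the data shown here, compound 2 `CC(C)(C)c1ccc(C(=O)NCc2ccc(S(C)(=O)=O)cc2)cc1` gives 3800 nM in an assay on HeLa cells with Bile acid receptor (Homo sapiens) as the target, read by a luciferase reporter, with a stated time of 24 h (on this read-out lower numbers stand for an effect already at smaller amounts and higher numbers for an effect only at larger amounts of compound), the highest of the two numbers measured so far; its nearest neighbour, compound 1 `CC(C)(C)c1ccc(C(=O)NCc2ccc(OC(F)(F)F)cc2)cc1`, gives 160 nM. The step of a 24-fold higher number from compound 1 to compound 2 (1.38 log units; beyond the scatter) shows that swapping one group at this aromatic carbon can move the read-out a long way. Compound 3 `CC(C)(C)c1ccc(C(=O)NCc2ccc(CCC(=O)O)cc2)cc1` carries the next change: 2-carboxyethyl in place of methylsulfonyl on an aromatic carbon. Among the measured compounds shown here, only that single step bears on it, and it runs in the direction of a weaker effect; the new group is again a polar substituent, so a modest downward step a 1.5-fold lower number from compound 2 to compound 3 (0.18 log units; within the scatter) is expected rather than a large one. Compound 3 is therefore estimated at 2500 nM, between 500 nM and 12000 nM.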

Compound 3, half-maximal effective concentration: 350 nM
Estimate against measurement, compound 3: 7.1-fold (0.85 log units) above; the whole stated range lies above it.
By their numbers in this assay, from the lowest: compound 1; then compound 3; then compound 2.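

At this aromatic carbon, para to a large group, the poor result with methylsulfonyl does not extend to every replacement: 2-carboxyethyl gives an 11-fold lower number from compound 2 to compound 3 (1.04 log units; beyond the scatter) and recovers most of the lost ground. It still falls modestly short of trifluoromethoxy, with a 2.2-fold higher number from compound 1 to compound 3 (0.34 log units; beyond the scatter), so the three groups now form a clear order at this one position. Nothing measured here accounts for these differences.

Still open, going by these compounds, is whether the end group or the chain matters more. An amine, an amide or a longer chain ending in a carboxylic acid at this carbon would help separate the two.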